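Swapping the Sulfonamide Ring: A Fluorine for a Methyl

The compounds below may be only part of what the source reports. "The series", "measured", "known", "first", "only" and "open" are said of these compounds alone.

Compound 2 `Cc1cccc(S(=O)(=O)NCc2ccc(CNC(=O)c3cccnc3)cc2)c1` is measured in an assay on MDA-MB-231 cells for displacement of a labelled ligand from C-X-C chemokine receptor type 4 (Homo sapiens), read by fluorescence and microscopy, with stated times of 10 min and 30 min (on this read-out lower numbers stand for an effect already at smaller amounts and higher numbers for an effect only at larger amounts of compound), at 10 nM, level with compound 1 `Cc1ccccc1C(=O)NCc1ccc(CNS(=O)(=O)c2ccccc2C)cc1` at 10 nM; together they give the lowest numbers of the three. Compound 3 `COc1ccccc1C(=O)NCc1ccc(CNS(=O)(=O)c2cccc(C)c2)cc1` gives 1000 nM, and the change a 100-fold higher number from compound 2 to compound 3 (2.00 log units; beyond the scatter) shows that the carbonyl side is sensitive. Compound 4 `O=C(NCc1ccc(CNS(=O)(=O)c2ccc(F)cc2)cc1)c1cccnc1` differs from compound 2 on the other side: 4-fluorophenyl in place of 3-methylphenyl on a sulfonyl sulfur. For the measured compounds named here, no measured step touches the sulfonyl side alone; compounds 1 and 2 differ in two places yet give equal numbers, which hints that this side tolerates small changes. Compound 4 is therefore expected to show a 2.0-fold higher number from compound 2 to compound 4 (0.30 log units; within the scatter), at most a step within the scatter, with an estimated value of 20 nM ranging from 5 nM to 100 nM.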

Compound 4, effective concentration (reported as EC, without a stated level of effect): 100 nM
The estimate for compound 4 lay 5.0-fold (0.70 log units) below the measured number; the range from low to high includes it.
By their numbers in this assay, from the lowest: compounds 1 and 2 (each within the scatter of the next); then compound 4; then compound 3.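

The sulfonyl side is less forgiving than compounds 1 and 2 hinted: in this assay, 4-fluorophenyl in place of 3-methylphenyl on a sulfonyl sulfur gives a 10-fold higher number from compound 2 to compound 4 (1.00 log units; beyond the scatter). This single change keeps the heavy-atom count and the aromatic ring, yet it still moves the number beyond the scatter. Nothing available accounts for this step.

Still open, on these data alone, is whether losing the methyl or gaining the fluorine matters more. Also open, as far as these compounds go, is how an amine or a carboxylic acid on this ring would fare.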